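The compounds below may be only part of what the source reports. "The series", "measured", "known", "first", "only" and "open" are said of these compounds alone.

Compound 2 `CCCSc1nc(Cl)c2c(n1)N(Cc1ccccc1)C(C(=O)N1CCN(C)CC1)N2` carries a 4-methylpiperazin-1-yl group on the carbonyl carbon of its amide. In a functional assay on TE-1 cells (Homo sapiens) for antiproliferative activity, read by MTT assay, with a stated time of 72 h (a lower number here means a stronger inhibitor, a higher number a weaker inhibitor), compound 2 gives 42500 nM. Compound 1 `CCCSc1nc(Cl)c2c(n1)N(Cc1ccccc1)C(C(=O)NCCC1=CCc3ccccc31)N2`, which bears a different amide group on the same shared core, gives 30000 nM in this assay. These two numbers lie within the usual scatter of each other, so neither compound can be called the weaker of the pair; both are weak inhibitors. Compound 3 `CCCSc1nc(Cl)c2c(n1)N(Cc1ccccc1)C(C(=O)NCC(C)C)N2` has not yet been measured. It differs from compound 2 in one place: isobutylamino in place of 4-methylpiperazin-1-yl on a carbonyl carbon. Among the compounds with values here, no measured pair shows this change, so there is no step to lean on. Because compound 2 gives 42500 nM and compound 1 gives 30000 nM, both far from potent, a number of the same order is expected. The expected step is therefore a 1.2-fold lower number from compound 2 to compound 3 (0.08 log units; within the scatter), with no direction beyond the scatter. Compound 3 is estimated at 35000 nM, within a range from 15000 nM to 80000 nM.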

Compound 3, half-maximal inhibitory concentration: 46600 nM
For compound 3 the middle estimate is 1.3-fold (0.12 log units) below the measured one; the measured number falls inside the stated range.
By their numbers in this assay, from the lowest: compounds 1, 2 and 3 (each within the scatter of the next).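

In this assay, within the data shown here, isobutylamino in place of 4-methylpiperazin-1-yl on this carbonyl carbon gives a 1.1-fold higher number from compound 2 to compound 3 (0.04 log units; within the scatter) and so offers the first direct reading of this change: a chain without a ring and a six-membered ring cannot be told apart here. The other new step, a group of 3 heavy atoms in place of a group of 10 heavy atoms on the amide chain, gives a 1.6-fold higher number from compound 1 to compound 3 (0.19 log units; within the scatter) and likewise separates nothing, so all three amide groups shown lie within the scatter of one another. Nothing measured here explains why these amide groups read alike. The compounds shown leave open whether any amide group at this position can give a clearly lower number, for example one with an amine or a carboxylic acid at the end of a longer chain. They also leave open whether changes elsewhere on the shared core would do so.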